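Cyclopropyl in Place of Ethoxy: An Expected Cytotoxicity Step

The source may report more compounds than this note shows. Statements on the series, on what has been measured and on what is new or still open speak of the compounds shown alone.

Compound 3 `CCOc1ccsc1CN[C@@H]1C[C@H]2C[C@@H]([C@H]1C)C2(C)C` carries an ethoxy group on the five-membered aromatic ring with 1 sulfur. In an ADME assay on MDCK cells (Canis lupus familiaris) for cytotoxicity, read by microscopy, with a stated time of 48 h (on this read-out higher numbers stand for lower toxicity in this test and lower numbers for higher toxicity in this test), compound 3 gives 50000 nM. It stands level with compound 2 `C[C@H]1[C@H](NCc2sccc2Br)C[C@H]2C[C@@H]1C2(C)C`, which in this assay gives 50000 nM; together they hold the highest of the three numbers, and no change at the digits printed from compound 2 to compound 3 (within the scatter). The furthest is compound 1 `C[C@H]1[C@H](NCc2sccc2-c2ccccc2)C[C@H]2C[C@@H]1C2(C)C`, which in this assay gives 12500 nM; a 4.0-fold higher number from compound 1 to compound 3 (0.60 log units; beyond the scatter), and likewise a 4.0-fold higher number from compound 1 to compound 2 (0.60 log units; beyond the scatter).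

Compound 4 `C[C@H]1[C@H](NCc2sccc2C2CC2)C[C@H]2C[C@@H]1C2(C)C` differs from compound 3 in one place: cyclopropyl in place of ethoxy on an aromatic carbon. Among the measured compounds shown here, no measured step involves a cyclopropyl group, so none bears directly on this change. The two steps that do exist show that phenyl, an aromatic carbon ring, gives a lower number than either ethoxy or bromo, while ethoxy and bromo do not differ. Cyclopropyl is a non-aromatic carbon ring, so a small downward movement is plausible, but the data give no firm anchor.

Compound 4 is therefore expected to give about 35000 nM in this assay, with a range from 12000 nM to 80000 nM. This estimate means a 1.4-fold lower number from compound 3 to compound 4 (0.15 log units; within the scatter), a step expected to sit near the edge of the scatter.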

Compound 4, minimum cytotoxic concentration: 25000 nM
Compound 4: middle estimate off by 1.4-fold (0.15 log units), on the high side, and the stated range covers the measured number.
By their numbers in this assay, from the lowest: compounds 1, 4, 2 and 3 (each within the scatter of the next, the first and the last beyond it).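

In this assay the cyclopropyl group of compound 4 stands within the scatter of all three other groups measured at this position on the five-membered aromatic ring with 1 sulfur: ethoxy (a 2.0-fold lower number from compound 3 to compound 4 (0.30 log units; within the scatter)), bromo (a 2.0-fold lower number from compound 2 to compound 4 (0.30 log units; within the scatter)) and phenyl (a 2.0-fold higher number from compound 1 to compound 4 (0.30 log units; within the scatter)). The earlier compounds shown here formed two separate levels, with phenyl in compound 1 set apart from bromo and ethoxy by steps beyond the scatter, whereas compound 4 now lies within the scatter of both levels and leaves no clean division among the four. The change from ethoxy to cyclopropyl keeps 3 heavy atoms, removes the oxygen and the hydrogen-bond acceptor and adds a three-membered non-aromatic ring, and at this position that exchange stays within the scatter.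

No supporting evidence accounts for any of these steps. Going by these compounds, whether an amine, a carboxylic acid or a longer chain such as propoxy at this position would stay with these groups or fall outside their span remains open, as does how cyclopropyl would read on any other core.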